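Sulfonyl amide series: pyridyl swap on the ring amine

The source may hold more compounds than are shown below. What is called first, only, known or untested is meant among the compounds shown, and "the series" means these compounds.

Working notes on three measured entries and one open one. In an ADME assay on microsomes from liver (Rattus norvegicus) for metabolic stability, read by LC-MS, with a stated time of 15 min, tested at 1 uM (on this read-out lower numbers stand for a less stable compound and higher numbers for a more stable compound), compound 2 `O=C(CCS(=O)(=O)c1cccc2ncsc12)N1CCN(c2ccc(Cl)cn2)CC1` gives 31%, the highest of the two numbers in hand. Compound 3 `Cc1cc(F)cnc1N1CCN(C(=O)CCCc2cccc3ncoc23)[C@@H](C)C1` gives 0%, a number well below compound 2 and beyond the scatter; compound 3 shares no single-point relation with compound 2, so the two values are only set side by side. In this assay compound 1 `O=C(CCS(=O)(=O)c1cccc2ncsc12)N1CCN(c2ccnc(C(F)(F)F)c2)CC1` gives "not determined" (no result reported), so no number is reported for it.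

The open entry is compound 4 `O=C(CCS(=O)(=O)c1cccc2ncsc12)N1CCN(c2ccncc2F)CC1`. Relative to compound 2 the change is 3-fluoropyridin-4-yl in place of 5-chloropyridin-2-yl on an amine nitrogen in a ring. Among the measured compounds shown here, no measured pair in the set isolates this kind of exchange, so there is no step to lean on; the two aryl groups that leave and enter are counted as equal in size and in donors and acceptors.

Expectation: the step from compound 2 to compound 4 is estimated as a number 3 percentage points lower from compound 2 to compound 4 (within the scatter), that is, no change beyond the scatter. Compound 4 is expected to give 28%, with a range from 8% to 55%.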

Compound 4, percent of the compound remaining: 29%
Compound 4: middle estimate off by 1 percentage points, on the low side; the measured number falls inside the stated range.
By their numbers in this assay, from the lowest: compound 3; then compounds 4 and 2 (each within the scatter of the next).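

In this assay, among the compounds shown here, the exchange of 5-chloropyridin-2-yl for 3-fluoropyridin-4-yl on an amine nitrogen in a ring gives a number 2 percentage points lower from compound 2 to compound 4 (within the scatter), the only single-point step in the set. On this shared core the read-out therefore does not separate the two aryl groups, which are equal in heavy atoms, donors and acceptors and carry chlorine in one case and fluorine in the other. Nothing at hand bears on why the two groups read alike.

Still open, as far as these compounds go, is how the read-out responds to a group other than a halogen on the pyridine, such as a methoxy group or a nitrile, or to a plain phenyl ring in place of the pyridine. For the compounds shown here, also open is the effect of a longer chain in place of the one carrying the sulfonyl group.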